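The source may report more compounds than this note shows. Statements on the series, on what has been measured and on what is new or still open speak of the compounds shown alone.

In a functional assay on NCI-H1975 cells (Homo sapiens) for inhibition, read by MTT assay, with a stated time of 72 h (a lower number here means a stronger inhibitor, a higher number a weaker inhibitor), three compounds have been measured so far. Compound 1 `CN1CCN(c2cc(C(F)(F)F)nc(SCc3ccc(C(F)(F)F)cc3)n2)CC1` gives 23900 nM, compound 2 `CCN1CCN(c2cc(C(F)(F)F)nc(SCc3ccc(C(F)(F)F)cc3)n2)CC1` gives 15000 nM, and compound 3 `FC(F)(F)c1ccc(CSc2nc(Sc3ccccn3)cc(C(F)(F)F)n2)cc1` gives 23900 nM. Compound 3 therefore stands level with compound 1 and within the scatter of compound 2.

Compound 4 `FC(F)(F)c1ccc(CSc2nc(Sc3ncc(-c4ccncc4)s3)cc(C(F)(F)F)n2)cc1` alters one group of compound 3: 5-(pyridin-4-yl)-1,3-thiazol-2-yl in place of pyridin-2-yl on a sulfur. Within the data shown here, no measured step makes this exact change, so the evidence is indirect. Putting (pyridin-2-yl)sulfanyl in place of 4-methylpiperazin-1-yl gave no change at the digits printed from compound 1 to compound 3 (within the scatter), and the same swap for 4-ethylpiperazin-1-yl gave a 1.6-fold higher number from compound 2 to compound 3 (0.20 log units; within the scatter). Adding a methyl to the piperazine chain gave a 1.6-fold lower number from compound 1 to compound 2 (0.20 log units; within the scatter). None of these steps left the scatter, although the entering thiazole group has not been tested in this set. In this assay, the expected change is a 1.6-fold lower number from compound 3 to compound 4 (0.20 log units; within the scatter), which means no clear step beyond the scatter. Compound 4 is estimated at 15000 nM, with an expected range from 4000 nM to 40000 nM.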

Compound 4, half-maximal inhibitory concentration: 16700 nM
Beside the measured number, compound 4's estimate is 1.1-fold (0.05 log units) below it; measured number inside the range.
By their numbers in this assay, from the lowest: compounds 2, 4, 1 and 3 (each within the scatter of the next).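

Among these compounds, the step of a 1.4-fold lower number from compound 3 to compound 4 (0.16 log units; within the scatter) gives the first direct reading at this place, a sulfur whose other neighbour is an aromatic carbon, in this assay. Here 5-(pyridin-4-yl)-1,3-thiazol-2-yl, a much larger group that carries a five-membered aromatic ring as well as a six-membered one, stands in place of pyridin-2-yl, and the number stays within the scatter, so this enlargement gives no clear gain or loss in this read-out. No measurement available here speaks to why the number holds.

The two rings of the entering group are not separated, so a plain 1,3-thiazol-2-yl could show whether either ring matters alone. From the compounds shown here alone, it also remains open whether a group of another kind on this sulfur, such as an amine or a carboxylic acid, would move the number beyond the scatter.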